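The source may hold more compounds than are shown below. What is called first, only, known or untested is meant among the compounds shown, and "the series" means these compounds.

Working notes on the series tested in a functional assay on MDA-MB-231 cells (Homo sapiens) for inhibition, read by MTT assay, with a stated time of 72 h; a higher number here means a weaker inhibitor, a lower number a stronger inhibitor. Compound 1 `Nc1ncnc2c1c(-c1cnc3[nH]ccc3c1)nn2CCCCC(=O)NO` reports only a limit of the assay, > 50000 nM. Compound 3 `Nc1ncnc2c1c(-c1cnc3[nH]ccc3c1)nn2CCCCCCC(=O)NO` carries 2-(hydroxycarbamoyl)ethyl in place of hydroxycarbamoyl on a saturated chain carbon, four bonds along the chain from an aromatic nitrogen, and in this assay compound 3 gives 37700 nM. The step of an at least 1.3-fold lower number from compound 1 to compound 3 (0.12 log units; that floor lies within the scatter) is therefore known only as a floor; note (the limit of > 50000 nM in this assay, at which 2 of the 3 values shown sit). Compound 2 `Nc1nc2cc(-c3nn(CCC(=O)NO)c4ncnc(N)c34)ccc2o1` rests on a different core, and the difference between the two cores is not broken down here. In this assay compound 2 likewise reports only a limit, > 50000 nM. Compound 4 `Nc1nc2cc(-c3nn(CCCCC(=O)NO)c4ncnc(N)c34)ccc2o1` is not yet measured and carries 2-(hydroxycarbamoyl)ethyl in place of hydroxycarbamoyl on a saturated chain carbon, two bonds along the chain from an aromatic nitrogen, the same kind of change as that made from compound 1 to compound 3, but set two bonds along the chain from an aromatic nitrogen rather than four. On the strength of the floor an at least 1.3-fold lower number from compound 1 to compound 3 (0.12 log units; that floor lies within the scatter), for compound 4 the expected step is an at least 1.2-fold lower number from compound 2 to compound 4 (0.09 log units; that floor lies within the scatter). Compound 4 is accordingly estimated at 40000 nM, between 15000 nM and 100000 nM, with a real chance that only a limit is reported.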

Compound 4, half-maximal inhibitory concentration: 21200 nM
Compound 4: the middle estimate sits 1.9-fold (0.28 log units) above what was measured, and the stated range covers the measured number.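

In this assay, 2-(hydroxycarbamoyl)ethyl in place of hydroxycarbamoyl gives an at least 2.3-fold lower number from compound 2 to compound 4 (0.37 log units; beyond the scatter), so on the core of compound 2 this change lowers the number beyond the scatter. The same kind of change on the other core gives an at least 1.3-fold lower number from compound 1 to compound 3 (0.12 log units; that floor lies within the scatter), a floor that stays within the scatter, and the change sits at a different place along the chain, so the two pairs show at most a shared direction and do not show that the size of the step carries from one core to the other: the same change on two cores in this assay, an at least 1.3-fold lower number (0.12 log units; that floor lies within the scatter) from compound 1 to compound 3 and an at least 2.3-fold lower number (0.37 log units; beyond the scatter) from compound 2 to compound 4; the limit leaves it open whether they differ Neither step has a fixed size, since each starts from a limit of the assay: the limit of > 50000 nM in this assay, at which 2 of the 4 values shown sit.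

Still open is whether a longer chain on the core of compound 2 would lower the number further, as only two chain lengths are shown on each core. Also open, going by these compounds, is how a carboxylic acid in place of the hydroxycarbamoyl end group would read on either core.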